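Trifluoromethyl Replaced by Fluoro: Compound 4 Expected

A few compounds are considered here, and "the series" means these few. Any claim that something is new, unique, unknown or untested is made for them only; others in the source may bear on it.

Compound 1 `Nc1ccc(-c2nc3ccc(F)cc3s2)cc1Cl`: < 10 nM
Compound 2 `Cc1cc(-c2nc3ccccc3s2)ccc1N`: < 10 nM
Compound 3 `Nc1ccc(-c2nc3ccccc3s2)cc1C(F)(F)F`: 13200 nM

In a functional assay on cells (Cancer cell lines, Homo sapiens) for inhibition (a higher number here means a weaker inhibitor of growth, a lower number a stronger inhibitor of growth), compound 1 gives < 10 nM, a limit of the assay. Compound 2 likewise gives < 10 nM, also a limit. Compound 3 gives 13200 nM, the only number among the three shown; the other two sit at the limit of < 10 nM in this assay, at which 2 of the 3 values shown sit. Going by the values given here, the one measured step, an at least 1300-fold higher number from compound 2 to compound 3 (3.12 log units; beyond the scatter), introduced trifluoromethyl and weakened growth inhibition greatly.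

Compound 4 `Nc1ccc(-c2nc3ccccc3s2)cc1F` differs from compound 3 by fluoro in place of trifluoromethyl on an aromatic carbon. Among the compounds with values here, that single step is the only evidence bearing on the change: removing trifluoromethyl is expected to undo much of the loss it caused, so a large fall in this assay is expected, a 330-fold lower number from compound 3 to compound 4 (2.52 log units; beyond the scatter). Compound 4 is therefore estimated at 40 nM, in the range 5 nM to 400 nM.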

Compound 4, concentration for 50% growth inhibition: < 10 nM
Compound 4 was reported as a limit (the forecaster's own chance of this, stated with the estimate: 30%); at least 4.0-fold (0.60 log units) between middle value and limit.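

In this assay compound 4 gives < 10 nM, which is a limit of the assay. Fluoro in place of trifluoromethyl brings an at least 1300-fold lower number from compound 3 to compound 4 (3.12 log units; beyond the scatter), so at this position, ortho to an amino group, the large loss belongs to trifluoromethyl and is not shared by fluoro. The step between compound 2 and compound 4 cannot be read, and methyl and fluoro cannot be ranked here: the limit of < 10 nM in this assay, at which 3 of the 4 values shown sit.

The compounds shown leave open whether a methoxy group or a carboxylic acid at this position would keep growth inhibition or lose it as trifluoromethyl does. They also leave open what numbers compound 2 and compound 4 would give without the limit.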